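Swapping Fluoro for Trifluoromethoxy on a Shared Core

The source may report more compounds than this note shows. Statements on the series, on what has been measured and on what is new or still open speak of the compounds shown alone.

Of the compounds shown here, three built on the same core have been tested in a functional assay on Jurkat cells (Homo sapiens) for activation, with a stated time of 24 h; on this read-out lower numbers stand for an effect already at smaller amounts and higher numbers for an effect only at larger amounts of compound. Compound 1 `O=[N+]([O-])c1ccc(NCc2ccccc2O)cc1` and compound 2 `Oc1ccccc1CNc1ccc(N2CCCC2)cc1` each gave no number: in this assay compound 1 is reported as "not active" (no number reported), and compound 2 likewise as "not active" (no number reported). Compound 3 `Oc1ccccc1CNc1ccc(-c2ccc(F)cc2)cc1` is the only one of the three with a measured value, reading 3860 nM in this assay, so it stands alone among the numbers shown and no comparison between two measured values is possible yet.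

Compound 4 `Oc1ccccc1CNc1ccc(-c2ccc(OC(F)(F)F)cc2)cc1` differs from compound 3 in one place: trifluoromethoxy in place of fluoro on an aromatic carbon. Among the compounds with values here, no pair of measured compounds shows what such an exchange does on this core, so the expected size of the step rests only on the single value of compound 3. The change from compound 3 to compound 4 is expected to stay close to the usual scatter, estimated as a 1.3-fold lower number from compound 3 to compound 4 (0.11 log units; within the scatter) in this assay. Compound 4 is therefore estimated at 3000 nM in this assay, with a range from 1200 nM to 8000 nM, and a real chance remains that, like compound 1 and compound 2, it is reported without a number.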

Compound 4, half-maximal effective concentration: "not active" (no number reported)
The entry for compound 4 holds no number, and the estimate cannot be compared.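

In this assay, within the data shown here, compound 4 gives "not active" (no number reported) and compound 3 gives 3860 nM so no step between these two compounds can be read. No evidence shown here bears on this result. The compounds shown leave open how any other group in place of fluoro would read out on the shared core.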